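Side chain swap on the compound 3 scaffold

The source may report more compounds than this note shows. Statements on the series, on what has been measured and on what is new or still open speak of the compounds shown alone.

- Compound 1 `CNC(=O)C[C@@H]1C[C@@H](c2ccc(Cl)c(Cl)c2)[C@H](NC(=O)c2cc(-c3c(Cl)cnn3C)c(Cl)o2)CN1` gives 40 nM
- Compound 2 `Cn1ncc(Cl)c1-c1cc(C(=O)N[C@@H]2CN[C@H](CC(O)CO)C[C@H]2c2ccc(F)c(F)c2)oc1Cl` gives 100 nM
- Compound 3 `Cn1ncc(Cl)c1-c1cc(C(=O)N[C@@H]2CN[C@H](CCO)C[C@H]2c2ccc(F)c(F)c2)oc1Cl` gives 60 nM

All three values come from a functional assay on LNCaP cells (Homo sapiens) for antiproliferative activity; a lower number here means a stronger inhibitor, a higher number a weaker inhibitor. Compound 3, at 60 nM, sits within the scatter of both compound 1 and compound 2, so the numbers give it no clear rank against either one.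

The next compound to read is compound 4 `CNC(=O)C[C@@H]1C[C@@H](c2ccc(F)c(F)c2)[C@H](NC(=O)c2cc(-c3c(Cl)cnn3C)c(Cl)o2)CN1`. Its change from compound 3 is methylcarbamoyl in place of hydroxymethyl on a saturated chain carbon bound to a saturated ring carbon. The same difference, cut one bond further out, reads 2-hydroxyethyl to (methylcarbamoyl)methyl.

Within the data shown here, only one measured step changes this side chain: a 1.7-fold lower number from compound 2 to compound 3 (0.22 log units; within the scatter). That step stays within the scatter, so it offers no sign that this assay responds strongly to changes on this chain. It involves a different change, however, so it bears on the present swap only indirectly. Compound 1 also carries methylcarbamoyl on its chain and gives 40 nM. It is not a single-place neighbour of compound 3, so this value serves as a reference only.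

No step beyond the scatter is expected in either direction. The expected change is a 1.2-fold lower number from compound 3 to compound 4 (0.08 log units; within the scatter). For compound 4 the estimated value is 50 nM, with an expected range of 22 nM to 115 nM.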

Compound 4, half-maximal inhibitory concentration: 50 nM
For compound 4 middle estimate and measured number coincide at the digits printed; low and high end bracket the measured number.
By their numbers in this assay, from the lowest: compounds 1, 4, 3 and 2 (each within the scatter of the next, the first and the last beyond it).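

In this assay, methylcarbamoyl in place of hydroxymethyl on a saturated chain carbon bound to a saturated ring carbon gives a 1.2-fold lower number from compound 3 to compound 4 (0.08 log units; within the scatter) and stays within the scatter. Methylcarbamoyl in place of 1,2-dihydroxyethyl at the same place gives a 2.0-fold lower number from compound 2 to compound 4 (0.30 log units; within the scatter) and also stays within the scatter, so this place tolerates both hydroxyl-ended chains and the methylcarbamoyl-ended chain in this series, with no separable difference among compound 2, compound 3 and compound 4. Compound 4 also opens a reading at a second place: 3,4-difluorophenyl in place of 3,4-dichlorophenyl on a saturated ring carbon gives a 1.3-fold higher number from compound 1 to compound 4 (0.10 log units; within the scatter) and shows no separable difference either, and nothing shown accounts for any of these small steps.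

All chains shown end in hydroxyl or methylcarbamoyl, so it remains open whether a chain ending in an amine or a carboxylic acid, or a longer chain, would give a step beyond the scatter. As far as these compounds go, it also remains open whether the aryl swap reads the same with a hydroxyl-ended chain, as 3,4-dichlorophenyl appears here only with the methylcarbamoyl-ended chain.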